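Adding Allyl to the Nitrogen of Compound 3

The compounds below may be only part of what the source reports. "The series", "measured", "known", "first", "only" and "open" are said of these compounds alone.

Of the compounds shown here, three have been read so far in an ADME assay on L6 cells (Rattus norvegicus) for cytotoxicity, read by fluorescence and resazurin assay, with a stated time of 72 h (a lower number here means that less compound is tolerated, a higher number that more compound is tolerated), and they set the frame for a fourth. Compound 1 (`Clc1ccc(C(c2c[nH]cc2-c2ccc(Cl)cc2-n2cccc2)n2ccnc2)c(Cl)c1`) gives 7670 nM here, and compound 2 (`Clc1ccc(C(c2c[nH]cc2-c2ccc(Cl)cc2-c2ccccc2)n2ccnc2)cc1`) gives 14900 nM on the same read-out. Compound 3 (`Clc1ccc(-c2cc(C(c3ccc(Cl)cc3)n3ccnc3)c[nH]2)cc1`) gives 6650 nM as its number, within the scatter of compound 1 and beyond the scatter below compound 2. Compound 4 (`C=CCn1cc(C(c2ccc(Cl)cc2)n2ccnc2)cc1-c1ccc(Cl)cc1`) differs from compound 3 by allyl in place of hydrogen on an aromatic nitrogen. For the measured compounds named here, no measured pair shows a change at this place, so in this assay no step beyond the scatter is expected, and the estimated step (a 1.1-fold lower number from compound 3 to compound 4 (0.04 log units; within the scatter)) has no firm direction. The estimate for compound 4 is 6000 nM (expected range 2200 nM to 16000 nM).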

Compound 4, half-maximal cytotoxic concentration: 7760 nM
Compound 4: the middle estimate sits 1.3-fold (0.11 log units) below what was measured, within the range that was stated.
By their numbers in this assay, from the lowest: compounds 3, 1, 4 and 2 (each within the scatter of the next, the first and the last beyond it).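

In this assay allyl in place of hydrogen on an aromatic nitrogen gives a 1.2-fold higher number from compound 3 to compound 4 (0.07 log units; within the scatter) and this first reading at this position stays within the scatter. In this one pair, then, the hydrogen on that nitrogen can be replaced by allyl with no step beyond the scatter. No available evidence bears on this result. As far as these compounds go, whether a longer chain, an amine or a carboxylic acid on this nitrogen would also stay within the scatter remains open. So does whether allyl would do the same on the core of compound 1 or compound 2.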